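A few compounds are considered here, and "the series" means these few. Any claim that something is new, unique, unknown or untested is made for them only; others in the source may bear on it.

Of the compounds shown here, two carry numbers so far. In a functional assay for antagonist activity at transient receptor potential cation channel subfamily V member 1 (Homo sapiens), read by FLIPR (on this read-out higher numbers stand for weaker inhibition and lower numbers for stronger inhibition), compound 1 `N#Cc1ccc(NC(=O)c2ccc(-c3ncccc3C(F)(F)F)cc2)cc1` gives 417 nM. Compound 2 `CCS(=O)(=O)Nc1cccnc1-c1ccc(C(=O)Nc2ccc(C(C)(C)C)cc2)cc1` has the lowest value of the two: in this assay compound 2 gives 49 nM, and the number of compound 1 stands above it by more than the scatter. Among the compounds with values here, no measured pair differs in a single place, so no step is yet known.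

Compound 3 `CC(C)(C)c1ccc(NC(=O)c2ccc(-c3ncccc3-c3nnco3)cc2)cc1` is the next to be measured. It differs from compound 2 in one place: 1,3,4-oxadiazol-2-yl in place of (ethylsulfonyl)amino on an aromatic carbon. Within the data shown here, the group that leaves holds the one hydrogen-bond donor that compound 2 has in this position; the group that enters is an aromatic ring and brings none. Among the measured compounds shown here, with no comparable step on record, the expected direction is a moderate move towards weaker inhibition, from compound 2 to compound 3 a 3.1-fold higher number from compound 2 to compound 3 (0.49 log units; beyond the scatter). For compound 3 the estimate in this assay is 150 nM, within a range from 40 nM to 600 nM.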

Compound 3, half-maximal inhibitory concentration: 91 nM
The estimate for compound 3 lay 1.6-fold (0.22 log units) above the measured number; low and high end bracket the measured number.
By their numbers in this assay, from the lowest: compounds 2 and 3 (each within the scatter of the next); then compound 1.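

In this assay, replacing (ethylsulfonyl)amino with 1,3,4-oxadiazol-2-yl on this aromatic carbon, ortho to a large group, gives a 1.9-fold higher number from compound 2 to compound 3 (0.27 log units; within the scatter), so the two compounds cannot be told apart. In this one pair, the hydrogen-bond donor held by the group that leaves can go, and a five-membered aromatic ring can take its place, with no step beyond the scatter. No measurement bears on why the two groups read alike.

On these data alone, whether an amine, a carboxylic acid or a longer chain on the sulfonyl group would read alike on this carbon stays open. Compound 1 differs from compound 2 and compound 3 in more than one place, so the trifluoromethyl group on this carbon cannot yet be compared on its own.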